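The compounds below may be only part of what the source reports. "The series", "measured", "known", "first", "only" and "open" are said of these compounds alone.

Measured compounds:
Compound 1 `O=C(/C=C/c1ccc2c(c1)B(O)OC2)c1ccc(-c2ccccc2)cc1` gives 4900 nM in a functional assay on SK-OV-3 cells (Homo sapiens) for cytotoxicity, read by MTT assay, with a stated time of 48 h; on this read-out lower numbers stand for stronger inhibition and higher numbers for weaker inhibition.
Compound 2 `O=C(/C=C/c1ccc2c(c1)B(O)OC2)c1cccnc1` gives 18500 nM in this assay.
Compound 3 `Cn1cccc1C(=O)/C=C/c1ccc2c(c1)B(O)OC2` gives 93600 nM in this assay.

Compound 3 gives the highest of the three numbers. Its nearest neighbour is compound 2, with a 5.1-fold higher number from compound 2 to compound 3 (0.70 log units; beyond the scatter), a change on the carbonyl carbon alone. Within the data shown here, compound 1 lies furthest away: compound 1 gives 4900 nM, while compound 3 gives 93600 nM, a wide gap, though no single step separates these two structures.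

Compound 4 `O=C(/C=C/c1ccc2c(c1)B(O)OC2)c1ccc(Cl)cc1` is the next structure. It differs from compound 3 in one place: 4-chlorophenyl in place of 1-methyl-1H-pyrrol-2-yl on a carbonyl carbon. Among the measured compounds shown here, the only measured step that bears on this position is the one from compound 2 to compound 3, which was modest and beyond the scatter. Compound 1, which also carries a six-membered carbon ring on the carbonyl carbon, gives the lowest number of the set. Compound 4 is therefore expected to move back toward the lower numbers, with a 16-fold lower number from compound 3 to compound 4 (1.19 log units; beyond the scatter). The estimate for compound 4 is 6000 nM, with a range from 2000 nM to 20000 nM.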

Compound 4, half-maximal inhibitory concentration: 3700 nM
Estimate against measurement, compound 4: 1.6-fold (0.21 log units) above; the range from low to high includes it.
By their numbers in this assay, from the lowest: compounds 4 and 1 (each within the scatter of the next); then compound 2; then compound 3.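

In this assay, replacing the 1-methyl-1H-pyrrol-2-yl group on the carbonyl carbon with 4-chlorophenyl produces a large step (a 25-fold lower number from compound 3 to compound 4 (1.40 log units; beyond the scatter)), showing how far the number can move at this position. The 4-chlorophenyl group also stands apart from pyridin-3-yl (a 5.0-fold lower number from compound 2 to compound 4 (0.70 log units; beyond the scatter)), so among compound 2, compound 3 and compound 4, the six-membered ring of carbon only goes with the lowest number. Chloro in place of phenyl on the aromatic carbon makes no difference that can be read (a 1.3-fold lower number from compound 1 to compound 4 (0.12 log units; within the scatter)), which lies within the scatter, so this assay does not separate the two groups.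

On these data alone, whether an amine or a carboxylic acid at that aromatic carbon would give a similar number remains open, as does the effect of a plain phenyl on the carbonyl carbon. Nothing available accounts for these steps.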